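The compounds below may be only part of what the source reports. "The series", "measured", "known", "first", "only" and "open" are said of these compounds alone.

Measured compounds:
- compound 1 `CC(=O)N1c2ccccc2CCC1C(=O)Nc1ccccc1O` gives 49700 nM
- compound 2 `O=C(Nc1ccccc1O)C1CCc2ccccc2N1C(=O)c1ccccc1Cl` gives 36800 nM
- compound 3 `CC(=O)N1c2ccccc2CCC1C(=O)Nc1ccccc1C(F)(F)F` gives only a limit, > 80000 nM

All three were tested in a functional assay on NUGC-3 cells (Homo sapiens) for cytotoxicity, read by sulforhodamine B assay, with a stated time of 72 h; on this read-out lower numbers stand for stronger inhibition of growth and higher numbers for weaker inhibition of growth. Compound 1 and compound 2 share a core and differ by 2-chlorophenyl in place of methyl on a carbonyl carbon; that change made a 1.4-fold lower number from compound 1 to compound 2 (0.13 log units; within the scatter). The value for compound 3 is a limit of the assay, not a number, so the step of an at least 1.6-fold higher number from compound 1 to compound 3 (0.20 log units; that floor lies within the scatter) is known only as a floor. The cores of compound 1 and compound 3 differ by trifluoromethyl in place of hydroxy on an aromatic carbon.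

Compound 4 `O=C(Nc1ccccc1C(F)(F)F)C1CCc2ccccc2N1C(=O)c1ccccc1Cl` has not yet been measured in this assay. Within the data shown here, it differs from compound 3 by 2-chlorophenyl in place of methyl on a carbonyl carbon, which is the same change as the one from compound 1 to compound 2, made on the same kind of carbonyl carbon. From compound 1 to compound 2 that change stayed within the scatter, so a step of similar size is expected from compound 3 to compound 4, a number no higher from compound 3 to compound 4 (the limit leaves the size open). On these data alone, because compound 3 sits at the limit of > 80000 nM in this assay, at which 1 of the 3 values shown sits, the starting point itself is unknown, and a step of that size may well leave compound 4 at the limit again. Compound 4 is therefore expected to give about 80000 nM in this assay, with a likely range from 40000 nM to 200000 nM, and a fair chance that only a limit is reported.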

Compound 4, concentration for 50% growth inhibition: 2730 nM
The estimate for compound 4 lay 29-fold (1.47 log units) above the measured number; the whole stated range lies above it.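

In this assay, 2-chlorophenyl in place of methyl on the carbonyl carbon gave an at least 29-fold lower number from compound 3 to compound 4 (1.46 log units; beyond the scatter), so this change did not carry over from one core to the other at a fixed size: the same change on two cores in this assay, a 1.4-fold lower number (0.13 log units; within the scatter) from compound 1 to compound 2 and an at least 29-fold lower number (1.46 log units; beyond the scatter) from compound 3 to compound 4, at least 21-fold (1.33 log units) apart, beyond the scatter of two such steps

The second change behaves in the same way, with trifluoromethyl in place of hydroxy on the aromatic carbon giving a 13-fold lower number from compound 2 to compound 4 (1.13 log units; beyond the scatter), so the effect of each change here depends on which group sits at the other place: the same change on two cores in this assay, an at least 1.6-fold higher number (0.20 log units; that floor lies within the scatter) from compound 1 to compound 3 and a 13-fold lower number (1.13 log units; beyond the scatter) from compound 2 to compound 4, at least 21-fold (1.33 log units) apart, beyond the scatter of two such steps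

What this does not show is why the two changes differ from one core to the other, and the exact size of the gap stays unknown, for compound 3 gives only a limit of the assay: the limit of > 80000 nM in this assay, at which 1 of the 4 values shown sits.

The compounds shown leave open whether the large gain needs the chlorine of the 2-chlorophenyl group, which a plain phenyl on the carbonyl carbon would test, or whether a longer chain such as propanoyl in place of the acetyl methyl would do something similar. They also leave open whether a group other than trifluoromethyl and hydroxy on the aromatic carbon, such as an amine or a carboxylic acid, would pair with 2-chlorophenyl in the same way.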